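This account rests on a few compounds, and the source may have more. Where it says the series, first, only, none or still open, it means among the compounds named here.

compound 1 `O=c1[nH]cc(S(=O)(=O)Nc2ccccc2-c2cn(-c3cccc(Cl)c3)nn2)c(=O)[nH]1` gives 2460 nM
compound 2 `O=c1[nH]cc(S(=O)(=O)Nc2cccc(-c3cn(-c4ccccc4)nn3)c2)c(=O)[nH]1` gives 11200 nM

In a functional assay on HepG2 cells (Homo sapiens) for antiproliferative activity, read by MTT assay, with a stated time of 24 h (on this read-out lower numbers stand for stronger inhibition and higher numbers for weaker inhibition), compound 2 stands at the highest of the two numbers; its nearest neighbour is compound 1, whose lower number lies beyond the scatter. Among the measured compounds shown here, the two differ in more than one place, so no single step between them is known. Compound 3 `O=c1[nH]cc(S(=O)(=O)Nc2cccc(-c3cn(-c4cccc(Cl)c4)nn3)c2)c(=O)[nH]1` differs from compound 2 by chloro in place of hydrogen on an aromatic carbon. For the measured compounds named here, no step of this kind between measured compounds is known, so only a modest lowering is expected, a 1.9-fold lower number from compound 2 to compound 3 (0.27 log units; within the scatter). Compound 3 is therefore estimated at 6000 nM, with a range from 2000 nM to 18000 nM.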

Compound 3, half-maximal inhibitory concentration: 4200 nM
The estimate for compound 3 lay 1.4-fold (0.15 log units) above the measured number; low and high end bracket the measured number.
By their numbers in this assay, from the lowest: compounds 1 and 3 (each within the scatter of the next); then compound 2.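

In this assay, among the compounds shown here, the change from phenyl to 3-chlorophenyl gives a 2.7-fold lower number from compound 2 to compound 3 (0.43 log units; beyond the scatter) as the first single-place step. This aromatic carbon therefore accepts a chloro group, and the number falls by a modest step beyond the scatter. Nothing measured here accounts for the size of this step.

On these data alone, whether fluoro, methoxy, an amine or a carboxylic acid on the same carbon would lower the number further remains open. As far as these compounds go, it is also open whether the same step would hold on the core of compound 1.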